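Working notes: from compound 1 to compound 4

This account rests on a few compounds, and the source may have more. Where it says the series, first, only, none or still open, it means among the compounds named here.

In an ADME assay on Huh-7 cells (Homo sapiens) for cytotoxicity, read by MTT assay, with a stated time of 72 h (on this read-out lower numbers stand for higher toxicity in this test and higher numbers for lower toxicity in this test), compound 1 (`Cc1cc(=O)oc2cc(OCc3cn(-c4ccccc4F)nn3)ccc12`) gives > 100 ug/mL as a limit of the assay and not a number. Compound 2 (`COc1ccc(-n2cc(COc3ccc4c(C)cc(=O)oc4c3)nn2)c(OC)c1`) gives > 100 ug/mL as a limit of the same kind. Compound 3 (`Cc1cc(=O)oc2cc(OCc3cn(-c4ccc(Oc5ccccc5)cc4)nn3)ccc12`) gives > 100 ug/mL as a limit as well. Going by the values given here, compound 1 therefore has no numerical value and shares its position with the other two measured compounds, summed up as the limit of > 100 ug/mL in this assay, at which 3 of the 3 values shown sit, for the series so far.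

The next compound is compound 4 (`Cc1ccc(-n2cc(COc3ccc4c(C)cc(=O)oc4c3)nn2)c(Cl)c1`), which keeps the core of compound 1. It has 2-chloro-4-methylphenyl in place of 2-fluorophenyl on an aromatic nitrogen, counted as 2-chloro-4-methylphenyl in place of 2-fluorophenyl on an aromatic nitrogen for this change.

Among the compounds with values here, no measured step in this assay gives a size for such a change. The three measured compounds carry different groups at that place, yet all three read the same limit. The expected size of a step that the limit leaves unreadable from compound 1 to compound 4 in this assay is none beyond the scatter, and this expectation rests on compound 1 with its limit of > 100 ug/mL as the reference. A report at the limit is the most likely outcome. Compound 4 is estimated at 110 ug/mL with an expected range from 50 ug/mL to 200 ug/mL in this assay as the read-out.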

Compound 4, half-maximal cytotoxic concentration: > 100 ug/mL
Compound 4 was reported as a limit; the forecaster's own chance of this, stated with the estimate: 80%; the middle value lies beyond the limit too.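

In this assay compound 4 gives > 100 ug/mL, a limit of the assay and not a number. Compound 1 is also reported only as a limit, so no step can be read between compound 1 and compound 4. The compounds shown leave open whether the group on the aromatic nitrogen changes this read-out at all, with the whole series at one place: the limit of > 100 ug/mL in this assay, at which 4 of the 4 values shown sit.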